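Trifluoromethyl to tert-butoxy: working notes on the series

The source may hold more compounds than are shown below. What is called first, only, known or untested is meant among the compounds shown, and "the series" means these compounds.

- compound 1 `N#Cc1cnc(NCc2cnccc2C(F)(F)F)cc1NCCC1CCOCC1`: 0%
- compound 2 `CNC(=O)[C@H]1CC[C@@H](Nc2cc(NCc3cnccc3C(F)(F)F)ncc2C#N)CC1`: 53%
- compound 3 `N#Cc1cnc(NCc2cncnc2C(F)(F)F)cc1N[C@H]1CC[C@@H](O)CC1`: 76%

In an ADME assay on S9 fraction from liver (Rattus norvegicus) for metabolic stability, with a stated time of 1 h (on this read-out lower numbers stand for a less stable compound and higher numbers for a more stable compound), compound 3 stands highest of the three at 76%, with clear gaps to the other two. Compound 4 `CC(C)(C)Oc1ncncc1CNc1cc(N[C@H]2CC[C@@H](O)CC2)c(C#N)cn1` differs from compound 3 in one place: tert-butoxy in place of trifluoromethyl on an aromatic carbon. Among the measured compounds shown here, the one measured single-place step, a number 53 percentage points higher from compound 1 to compound 2 (beyond the scatter), was large but lies elsewhere on the molecule. For the measured compounds named here, it shows only that this read-out can move far, and no measured step covers this position. A moderate fall is expected, estimated as a number 21 percentage points lower from compound 3 to compound 4 (beyond the scatter), with its size poorly defined. Compound 4 is estimated at 55%, with an expected range of 25% to 80%.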

Compound 4, percent of the compound remaining: 21%
Beside the measured number, compound 4's estimate is 34 percentage points above it; the whole stated range lies above it.
By their numbers in this assay, from the lowest: compound 1; then compound 4; then compound 2; then compound 3.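

In this assay, tert-butoxy in place of trifluoromethyl on this aromatic carbon gives a number 55 percentage points lower from compound 3 to compound 4 (beyond the scatter). Among the compounds shown here, this is the first measured step at this position, and it shows that the read-out is highly sensitive to the group placed here. Nothing measured bears on the reason for the fall.

Only two groups are shown at this position, so it remains open whether a smaller ether such as methoxy, or a plain methyl, would keep the higher number of compound 3. Also open, on these data alone, is whether the change would have a step of similar size alongside 4-(methylcarbamoyl)cyclohexyl.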